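Chromone acrylamides: fluoro for methoxy on the anilide

The source may report more compounds than this note shows. Statements on the series, on what has been measured and on what is new or still open speak of the compounds shown alone.

Compound 1 `COc1ccc2c(=O)c(/C=C/C(=O)Nc3cccc(Cl)c3)coc2c1` in a functional assay (QGY7701 cells, Homo sapiens) for inhibition, read by MTT assay, with a stated time of 48 h; a higher number here means a weaker inhibitor, a lower number a stronger inhibitor: > 100000 nM (a limit).
Compound 2 `COc1cccc(NC(=O)/C=C/c2coc3cc(OC)ccc3c2=O)c1`: 39100 nM.
Compound 3 `COc1ccc(NC(=O)/C=C/c2coc3cc(OC)ccc3c2=O)cc1`: > 100000 nM (a limit).

Compound 3 sits at the assay limit, as does compound 1 (the limit of > 100000 nM in this assay, at which 2 of the 3 values shown sit). The change to compound 4 `COc1ccc2c(=O)c(/C=C/C(=O)Nc3ccc(F)cc3)coc2c1` is fluoro in place of methoxy on an aromatic carbon. Within the data shown here, no measured step covers fluoro against methoxy. The nearest are an at least 2.5-fold lower number from compound 1 to compound 2 (0.40 log units; beyond the scatter) and an at least 2.5-fold higher number from compound 2 to compound 3 (0.40 log units; beyond the scatter), both at least modest and both involving a limit, so they set no firm scale for compound 4. Given that compound 3 sits at the limit, compound 4 is expected to show an at least 1.1-fold lower number from compound 3 to compound 4 (0.04 log units; that floor lies within the scatter), with a real chance of another limit. Compound 4 is estimated at 90000 nM in this assay, in the range 20000 nM to 300000 nM.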

Compound 4, half-maximal inhibitory concentration: > 100000 nM
Compound 4 was reported as a limit (the forecaster's own chance of this, stated with the estimate: 55%); middle value at least 1.1-fold (0.04 log units) away from the limit.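

In this assay, 4-fluorophenyl in place of 3-methoxyphenyl on the amide nitrogen weakens the result, with an at least 2.5-fold higher number from compound 2 to compound 4 (0.40 log units; beyond the scatter). The steps to compound 4 from compound 1 and from compound 3 cannot be read, and fluoro para to a large group brings no value inside the readable range. The series now gathers at one point: the limit of > 100000 nM in this assay, at which 3 of the 4 values shown sit.

On these data alone, how far compound 1, compound 3 and compound 4 truly differ stays open. So does whether an amine or a carboxylic acid on this phenyl ring would give a readable value.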